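Swapping an Aminomethylphenyl Amide for a Thiazole Alcohol

A few compounds are considered here, and "the series" means these few. Any claim that something is new, unique, unknown or untested is made for them only; others in the source may bear on it.

Compound 1 `CC(C)(C)c1cc(C(=O)Nc2cccc(CN)c2)n(Cc2ccccc2)n1` is an amide whose nitrogen bears a 3-(aminomethyl)phenyl group. In a physicochemical assay for solubility, read by nephelometry, measured as kinetic solubility, at pH 6.5 (on this read-out lower numbers stand for lower solubility and higher numbers for higher solubility), compound 1 gives 25 ug/mL. Two smaller amides sit alongside it. Compound 3 `NCc1csc(NC(=O)c2ccccc2)n1` gives 25 ug/mL in this assay, which at the digits shown is level with compound 1 and within the usual scatter, so no order between the two can be read. Compound 2 `NCc1csc(NC(=O)c2ccn[nH]2)n1` reaches only a limit of the measurement, > 100 ug/mL in this assay, which is one of the values shown (the limit of > 100 ug/mL in this assay, at which 1 of the 3 values shown sits) and not a number. No pair of these compounds differs in a single place, so no measured step is available.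

Compound 4 `CC(C)(C)c1cc(C(=O)Nc2nc(CO)cs2)n(Cc2ccccc2)n1` keeps the core of compound 1 and changes the group on the amide nitrogen: 4-(hydroxymethyl)-1,3-thiazol-2-yl in place of 3-(aminomethyl)phenyl on an amide-type nitrogen. For the measured compounds named here, the data hold no measured step of this kind, so the expectation rests on the change alone. The step from compound 1 to compound 4 in this assay is expected to be a modest loss, a 2.5-fold lower number from compound 1 to compound 4 (0.40 log units; beyond the scatter), somewhat beyond the scatter but not large. Compound 4 is therefore estimated at 10 ug/mL, with a range from 3 ug/mL to 40 ug/mL in this assay.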

Compound 4, solubility: 3.1 ug/mL
Compound 4: middle estimate off by 3.2-fold (0.51 log units), on the high side, and the stated range covers the measured number.
By their numbers in this assay, from the lowest: compound 4; then compounds 1 and 3 (each within the scatter of the next). At a limit, above all of these: compound 2.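

This result supplies the only measured step among the compounds shown: with the core of compound 1 held fixed, placing 4-(hydroxymethyl)-1,3-thiazol-2-yl in place of 3-(aminomethyl)phenyl on the amide-type nitrogen gives an 8.1-fold lower number from compound 1 to compound 4 (0.91 log units; beyond the scatter) in this assay. So the read-out at this position responds to the group on the amide nitrogen, even though the computed counts show one hydrogen-bond donor and no net charge for both the group that leaves and the group that enters. Nothing measured here accounts for the size of the step.

The change replaces the ring and its side chain in a single move, so the compounds shown leave open how much of the step belongs to the five-membered ring with its two hetero atoms and how much to the hydroxymethyl group that replaces the aminomethyl group. A 3-(hydroxymethyl)phenyl group on the same nitrogen would change only the side chain, and a 4-(aminomethyl)-1,3-thiazol-2-yl group would change only the ring, so the pair would separate the two parts.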